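Nitro substitution on the aryl ring of the oxazolone series

This account rests on a few compounds, and the source may have more. Where it says the series, first, only, none or still open, it means among the compounds named here.

Compound 2 `O=C1OC(c2ccccc2)=N/C1=C\c1ccncc1` is the unsubstituted reference of this pair. In an assay on isolated protein for inhibition of Death-associated protein kinase 3 (Homo sapiens), tested at 1 uM (a lower number here means a weaker effect, a higher number a stronger effect of the compound at the concentration tested), compound 2 gives 0%, level with compound 1 `O=C1OC(c2ccc(Cl)c([N+](=O)[O-])c2)=N/C1=C\c1ccncc1`, which in this assay gives 0%; the two lie within the scatter. Compound 3 `O=C1OC(c2cccc([N+](=O)[O-])c2)=N/C1=C\c1ccncc1` differs from compound 2 by nitro in place of hydrogen on an aromatic carbon. Going by the values given here, no step between measured compounds is available; compound 1, which also carries a nitro group, shows 0%, so no step beyond the scatter is expected here. Compound 3 is expected to give 0% (range -5% to 10%). The expected step is no change at the digits printed from compound 2 to compound 3 (within the scatter).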

Compound 3, a percentage reported as inhibition, at one concentration (the size of the read-out at that concentration, not a potency): 0%
Compound 3: middle estimate and measured number agree at the digits printed; measured number inside the range.
By their numbers in this assay, from the lowest: compounds 1, 2 and 3 (each within the scatter of the next).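

In this assay, going by these compounds alone, nitro in place of hydrogen on an aromatic carbon, meta to a large group, gives no change at the digits printed from compound 2 to compound 3 (within the scatter), the first direct reading of this change. Hydrogen in place of chloro, with the nitro group kept, gives no change at the digits printed from compound 1 to compound 3 (within the scatter), so neither change moves the read-out beyond the scatter. No supporting data bear on the flat read-out.

Still open, as far as these compounds go, is whether an amine or a carboxylic acid on that aromatic carbon would give a read-out different from that of compound 3 at 0%. From the compounds shown here alone, whether changes elsewhere on the shared core would register in this assay also remains open.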